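The source may report more compounds than this note shows. Statements on the series, on what has been measured and on what is new or still open speak of the compounds shown alone.

Measured so far:
Compound 1 `COc1ccc2[nH]c(C(=O)N3CC(=O)N(Cc4ccccc4)[C@@H](CN4CCC5(CC4)CC5)C3)cc2c1` gives 28200 nM in a physicochemical assay for solubility, read by spectrophotometry, in phosphate buffer, with a stated time of 2 h, at pH 7.4; a lower number here means a less soluble compound, a higher number a more soluble compound.
Compound 2 `COc1cccc(CN2C(=O)CN(C(=O)c3cc4cc(OC)ccc4[nH]3)C[C@@H]2COCc2ccccc2)c1` gives 11700 nM in this assay.

Of the two numbers in hand, compound 2 stands lowest: compound 1 sits a clear step higher, a gap beyond the usual scatter. The two compounds differ in more than one place, so this gap cannot be tied to any single change.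

Compound 3 `COc1ccc2[nH]c(C(=O)N3CC(=O)N(Cc4ccccc4)[C@@H](COCc4ccccc4)C3)cc2c1` is the next structure of interest. It is derived from compound 2 by a single change: hydrogen in place of methoxy on an aromatic carbon. Nothing else on the core or the substituents moves.

For the measured compounds named here, no pair of measured compounds shows this particular change, so its effect in this assay has no direct precedent here. With only the methoxy leaving and a hydrogen entering, a step of modest size is the reasonable expectation, in either direction or none beyond the scatter. For compound 3 the value expected in this assay is 12000 nM, with a range from 5000 nM to 30000 nM. This estimate means a step of a 1.0-fold higher number from compound 2 to compound 3 (0.01 log units; within the scatter) that stays within the usual scatter.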

Compound 3, solubility: 8800 nM
The estimate for compound 3 lay 1.4-fold (0.13 log units) above the measured number, and the stated range covers the measured number.
By their numbers in this assay, from the lowest: compounds 3 and 2 (each within the scatter of the next); then compound 1.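

In this assay the 3-methoxybenzyl group of compound 2 gives way to the benzyl group of compound 3 with a step of a 1.3-fold lower number from compound 2 to compound 3 (0.12 log units; within the scatter), so at this place on the ring the methoxy can go without a change that this read-out can separate from repeat measurement. For the compounds shown here, compound 3 also gives the first single-place comparison with compound 1: the exchange of the group on the saturated chain carbon, from the one with a three-membered and a six-membered non-aromatic ring to the one with a six-membered aromatic ring, is a 3.2-fold lower number from compound 1 to compound 3 (0.51 log units; beyond the scatter), so the group at that carbon marks a place where the number moves beyond the scatter, which the earlier pair could not show. No supporting measurement is available to explain either step.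

These compounds leave open whether other groups on the benzyl ring, such as a fluorine atom or a carboxylic acid, would also stay within the scatter. They also leave open how a simple amine such as dimethylamino at the saturated chain carbon would compare with the group of compound 1 in this assay.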